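Swapping a cyclopropylmethoxy chain for a fluorinated one

The source may hold more compounds than are shown below. What is called first, only, known or untested is meant among the compounds shown, and "the series" means these compounds.

The measure here is an ADME assay on Vero C1008 cells (Chlorocebus sabaeus) for cytotoxicity, read by MTT assay, with a stated time of 72 h; a higher number here means that more compound is tolerated, a lower number that less compound is tolerated. Compound 3 `Cn1cc(-c2cc(-c3cc(Cl)cc(OCC4CC4)c3)c(=O)n(-c3cccnc3)c2)c(=O)[nH]c1=O` gives 82000 nM, the higher of the two plain numbers seen so far. Compound 1 `N#Cc1ccccc1-c1cc(-c2cc(Cl)cc(OCCC(F)(F)F)c2)c(=O)n(-c2cccnc2)c1` gives 22000 nM, a gap from compound 3 that lies beyond the usual scatter. Compound 2 `O=c1[nH]cc(-c2cc(-c3cc(Cl)cc(OCc4ocnc4C(F)(F)F)c3)c(=O)n(-c3cccnc3)c2)c(=O)[nH]1` gives > 100000 nM; for compound 2 the result is a limit of the assay and not a number, namely (the limit of > 100000 nM in this assay, at which 1 of the 3 values shown sits).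

Compound 4 `Cn1cc(-c2cc(-c3cc(Cl)cc(OCCC(F)(F)F)c3)c(=O)n(-c3cccnc3)c2)c(=O)[nH]c1=O` has not yet been measured. It differs from compound 3 in one place: 2,2,2-trifluoroethyl in place of cyclopropyl on a saturated chain carbon bound to an oxygen on an aromatic ring. Compound 1 carries the same 3,3,3-trifluoropropoxy chain and gives 22000 nM, but the rest of its structure is different, so it is only a loose guide.

Among the compounds with values here, with no directly comparable step to lean on, the expected step from compound 3 to compound 4 is a modest move toward a lower number, close to the edge of the scatter, a 1.6-fold lower number from compound 3 to compound 4 (0.21 log units; within the scatter). The value for compound 4 is estimated at 50000 nM, with a likely range from 20000 nM to 100000 nM.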

Compound 4, half-maximal cytotoxic concentration: > 100000 nM
Compound 4: only a limit was reported (the forecaster's own chance of this, stated with the estimate: 20%); middle value at least 2.0-fold (0.30 log units) from the limit.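

In this assay compound 4 gives > 100000 nM, which is a limit of the assay and not a number. The change at this position reads as an at least 1.2-fold higher number from compound 3 to compound 4 (0.08 log units; that floor lies within the scatter), so replacing the cyclopropylmethoxy chain with the 3,3,3-trifluoropropoxy chain brings no visible loss in the amount of compound tolerated, although this floor alone does not establish a real rise. With the 3,3,3-trifluoropropoxy chain held the same, changing the group on the aromatic carbon gives an at least 4.5-fold higher number from compound 1 to compound 4 (0.65 log units; beyond the scatter), so the earlier lower number goes with that group and not with the fluorinated chain.

Going by these compounds, the true size of the chain step cannot be read, because the result stops at the limit: the limit of > 100000 nM in this assay, at which 2 of the 4 values shown sit. Whether a longer fluorinated chain or a chain ending in an amine would behave the same way remains open.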